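The compounds below may be only part of what the source reports. "The series", "measured", "known", "first", "only" and "open" are said of these compounds alone.

Measured in a functional assay on CHO cells for agonist activity at Free fatty acid receptor 1 (Homo sapiens), read by a luciferase reporter, with a stated time of 24 h; on this read-out lower numbers stand for an effect already at smaller amounts and higher numbers for an effect only at larger amounts of compound:
Compound 1 `O=C(O)CCc1ccc2[nH]c(-c3ccccc3C(F)(F)F)cc2c1` gives 1310 nM
Compound 2 `O=C(O)CCc1ccc2[nH]c(-c3ccccc3F)cc2c1` gives 1210 nM
Compound 3 `Cc1ncccc1-c1cc2cc(CCC(=O)O)ccc2[nH]1` gives > 25 nM

Compound 1 holds the highest of the two numbers shown, and its nearest neighbour is compound 2, with a 1.1-fold lower number from compound 1 to compound 2 (0.03 log units; within the scatter). The value of compound 3 is a limit of the assay rather than a number (the limit of > 25 nM in this assay, at which 1 of the 3 values shown sits). Compound 4 `O=C(O)CCc1ccc2[nH]c(-c3ccccc3Cl)cc2c1` differs from compound 1 by chloro in place of trifluoromethyl on an aromatic carbon. Among the measured compounds shown here, the only step that bears on this exchange is the one in which fluoro replaced trifluoromethyl, a 1.1-fold lower number from compound 1 to compound 2 (0.03 log units; within the scatter); the further step that the limit leaves unreadable from compound 2 to compound 3 cannot be read. A step no larger than the scatter is therefore expected in this assay, namely a 1.1-fold lower number from compound 1 to compound 4 (0.04 log units; within the scatter). Compound 4 is estimated at 1200 nM, with a range from 500 nM to 3000 nM.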

Compound 4, half-maximal effective concentration: 54.6 nM
Beside the measured number, compound 4's estimate is 22-fold (1.34 log units) above it; the whole stated range lies above it.
By their numbers in this assay, from the lowest: compound 4; then compounds 2 and 1 (each within the scatter of the next).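

In this assay, the group at this position matters more than the earlier pair suggested: trifluoromethyl and fluoro gave values within the scatter of each other, yet chloro brings a 24-fold lower number from compound 1 to compound 4 (1.38 log units; beyond the scatter) and a 22-fold lower number from compound 2 to compound 4 (1.35 log units; beyond the scatter). Heavy-atom count does not track this, since fluoro and chloro each have one heavy atom. Compound 3 carries a limit and not a number, so its step to compound 4 cannot be read: the limit of > 25 nM in this assay, at which 1 of the 4 values shown sits.

The compounds shown do not tell why chloro stands apart, nor whether bromo or methoxy in the same place would match it.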